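The compounds below may be only part of what the source reports. "The series", "measured", "known", "first", "only" and "open" are said of these compounds alone.

Measured so far in a toxicity assay on MDCK cells (Canis lupus familiaris) for cytotoxicity, read by CCK-8 assay, with a stated time of 48 h; on this read-out lower numbers stand for higher toxicity in this test and higher numbers for lower toxicity in this test:

- Compound 1 `CCCOc1ccc(C(=O)NNc2c(Br)cccc2Br)cc1`: the value of compound 1 is a limit of this assay, > 100000 nM.
- Compound 2 `O=C(NNc1c(Br)cccc1Br)c1ccc2ccccc2c1`: the value of compound 2 is also a limit, > 100000 nM.
- Compound 3 `CCOc1ccc(C(=O)NNc2c(Cl)cccc2Cl)cc1`: the value of compound 3 is likewise a limit, > 100000 nM.

Compound 1 therefore does not stand apart from the others: all three sit at the limit of > 100000 nM in this assay, at which 3 of the 3 values shown sit, and no number separates them.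

Compound 4 `CN(C)c1ccc(C(=O)NNc2c(Br)cccc2Br)cc1` is the next compound, not yet measured in this assay. It differs from compound 1 by dimethylamino in place of propoxy on an aromatic carbon. Among the compounds with values here, since every value shown is a limit, no measured step is available to calibrate the change. The expected step from compound 1 to compound 4, a step that the limit leaves unreadable from compound 1 to compound 4, is none beyond the scatter, and compound 4 is expected to sit again at or near the limit, estimated at 120000 nM within a range of 40000 nM to 400000 nM.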

Compound 4, half-maximal cytotoxic concentration: > 100000 nM
Compound 4: no number, only a limit; the forecaster's own chance of this, stated with the estimate: 80%; the middle value lies beyond the limit too.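

No step can be read between compound 1 and compound 4 in this assay, and both values are limits. All the compounds shown sit together: the limit of > 100000 nM in this assay, at which 4 of the 4 values shown sit.

The compounds shown leave open which change to the shared core, if any, would give a measurable cytotoxic concentration.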